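The source may hold more compounds than are shown below. What is called first, only, known or untested is meant among the compounds shown, and "the series" means these compounds.

Working notes on the series. Among the compounds with values here, compound 1 `Nc1nc(N)c2cc(CSC(=S)N3CCN(C4CCCCC4)CC3)ccc2n1` gives 6800 nM in a functional assay on MCF7 cells (Homo sapiens) for antiproliferative activity, read by MTT assay, with a stated time of 72 h (on this read-out higher numbers stand for weaker inhibition and lower numbers for stronger inhibition), the highest of the three numbers measured so far. Compound 2 `Cc1ccc(N2CCN(C(=S)SCc3ccc4nc(N)nc(N)c4c3)CC2)cc1` gives 2480 nM in this assay, and compound 3 `Nc1nc(N)c2cc(CSC(=S)N3CCN(c4ccc(F)cc4)CC3)ccc2n1` gives 1920 nM. Both measured steps that replace the cyclohexyl lower the number: a 2.7-fold lower number from compound 1 to compound 2 (0.44 log units; beyond the scatter) and a 3.5-fold lower number from compound 1 to compound 3 (0.55 log units; beyond the scatter). Between the two aryl compounds the gap is small, a 1.3-fold lower number from compound 2 to compound 3 (0.11 log units; within the scatter).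

Compound 4 `Nc1nc(N)c2cc(CSC(=S)N3CCN(c4ccc(F)cc4F)CC3)ccc2n1` is the unmeasured member. Against compound 1 the change is 2,4-difluorophenyl in place of cyclohexyl on an amine nitrogen in a ring. The two steps of a 2.7-fold lower number from compound 1 to compound 2 (0.44 log units; beyond the scatter) and a 3.5-fold lower number from compound 1 to compound 3 (0.55 log units; beyond the scatter) bear directly on it; both were modest and beyond the scatter, and the fluoro-for-methyl swap between them stayed within the scatter. Within the data shown here, a step of about the same size in this assay, toward a lower number, is therefore expected here; the second fluorine has no measured counterpart, so nothing further is assumed for it. Compound 4 is expected at 2000 nM, with a range from 900 nM to 4500 nM. The estimated step is a 3.4-fold lower number from compound 1 to compound 4 (0.53 log units; beyond the scatter).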

Compound 4, half-maximal inhibitory concentration: 3670 nM
Compound 4: the middle estimate sits 1.8-fold (0.26 log units) below what was measured; the measured number falls inside the stated range.
By their numbers in this assay, from the lowest: compounds 3, 2, 4 and 1 (each within the scatter of the next, the first and the last beyond it).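

In this assay, 2,4-difluorophenyl on the amine nitrogen in the ring gives a step within the scatter (a 1.9-fold lower number from compound 1 to compound 4 (0.27 log units; within the scatter)), so replacing cyclohexyl with an aryl group here does not always give a step beyond it, as it did for compounds 2 and 3. The further fluoro (a 1.9-fold higher number from compound 3 to compound 4 (0.28 log units; within the scatter)) and the change from 4-methylphenyl (a 1.5-fold higher number from compound 2 to compound 4 (0.17 log units; within the scatter)) also stay within the scatter, so the three aryl compounds are not separated by this read-out. No supporting data bear on these steps.

From the compounds shown here alone, it remains open whether a benzyl or 4-methoxyphenyl group on this nitrogen would stand beyond the scatter of compound 3. Going by these compounds, it also remains open whether a pyridyl ring there would separate from cyclohexyl more clearly than 2,4-difluorophenyl does.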